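Swapping the para substituent on a sulfonamide series

A few compounds are considered here, and "the series" means these few. Any claim that something is new, unique, unknown or untested is made for them only; others in the source may bear on it.

Measured so far:
Compound 1, `Cc1ccc(S(=O)(=O)Nc2ccc(-c3nc4ccccc4o3)cc2)cc1`, gives > 63000 nM in an assay on isolated protein for inhibition of malate dehydrogenase, mitochondrial (Sus scrofa), with stated times of 45 min and 30 min; on this read-out higher numbers stand for weaker inhibition and lower numbers for stronger inhibition; this is a limit of the assay, not a number.
Compound 2, `C=Cc1ccc(S(=O)(=O)Nc2ccc(-c3nc4ccccc4o3)cc2)cc1`, gives > 63000 nM in this assay; again a limit.
Compound 3, `CCc1ccc(S(=O)(=O)Nc2ccc(-c3nc4ccccc4o3)cc2)cc1`, gives > 63000 nM in this assay; again a limit.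

Compound 3 therefore stands at the limit of > 63000 nM in this assay, at which 3 of the 3 values shown sit. The new compound 4, `O=S(=O)(Nc1ccc(-c2nc3ccccc3o2)cc1)c1ccc(C(F)(F)F)cc1`, carries trifluoromethyl in place of ethyl on an aromatic carbon. Among the compounds with values here, the steps that bear on this change are a step that the two limits leave unreadable from compound 1 to compound 2, a step that the two limits leave unreadable from compound 1 to compound 3 and a step that the two limits leave unreadable from compound 2 to compound 3, none of which can be sized. With no readable step in hand, the expected step that the limit leaves unreadable from compound 3 to compound 4 is one that most likely stays at the limit. Compound 4 is estimated at 100000 nM, with a range from 30000 nM to 300000 nM.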

Compound 4, half-maximal inhibitory concentration: > 63000 nM
Compound 4: no number, only a limit (the forecaster's own chance of this, stated with the estimate: 85%); the middle value is on the limit's open side.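

Compound 4 gives only a limit, like compound 1, compound 2 and compound 3, so no step among these compounds can be read: the limit of > 63000 nM in this assay, at which 4 of the 4 values shown sit. The compounds shown leave open whether any substituent at this place gives a measurable value in this assay.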